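Swapping the benzyl arm: from compound 3 to compound 4

The source may report more compounds than this note shows. Statements on the series, on what has been measured and on what is new or still open speak of the compounds shown alone.

Compound 1 `COc1cc(Cn2cc(CNC(=O)c3cn(-c4ccccc4)nc3-c3ccc(F)cc3)nn2)cc(OC)c1`: 360 nM
Compound 2 `O=C(NCc1cn(Cc2ccc(Cl)cc2)nn1)c1cn(-c2ccccc2)nc1-c1ccc(Cl)cc1`: 470 nM
Compound 3 `O=C(NCc1cn(Cc2ccc(C(F)(F)F)cc2)nn1)c1cn(-c2ccccc2)nc1-c1ccc(Cl)cc1`: 1900 nM

In a functional assay on HeLa cells (Homo sapiens) for antiproliferative activity, read by sulforhodamine B assay, with a stated time of 48 h (a lower number here means a stronger inhibitor of growth, a higher number a weaker inhibitor of growth), compound 3 stands highest of the three numbers, beyond the scatter from both compound 2 and compound 1. Compound 4 `COc1cc(Cn2cc(CNC(=O)c3cn(-c4ccccc4)nc3-c3ccc(Cl)cc3)nn2)cc(OC)c1` differs from compound 3 by 3,5-dimethoxyphenyl in place of 4-(trifluoromethyl)phenyl on a saturated chain carbon bound to an aromatic nitrogen. Going by the values given here, the one measured step that bears on this same position is a 4.0-fold higher number from compound 2 to compound 3 (0.61 log units; beyond the scatter), a modest change, and it points toward the benzyl group mattering. Compound 1 carries the same 3,5-dimethoxybenzyl group on a core that differs from that of compound 4 in one place. Compound 1 gives 360 nM in this assay. Compound 4 is therefore expected to move back down, by roughly a 4.5-fold lower number from compound 3 to compound 4 (0.66 log units; beyond the scatter), to an estimated 420 nM with a range of 200 nM to 900 nM.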

Compound 4, concentration for 50% growth inhibition: 730 nM
Compound 4: the middle estimate sits 1.7-fold (0.24 log units) below what was measured, and the stated range covers the measured number.
By their numbers in this assay, from the lowest: compounds 1, 2 and 4 (each within the scatter of the next, the first and the last beyond it); then compound 3.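

In this assay the 3,5-dimethoxyphenyl group on this saturated chain carbon gives a 2.6-fold lower number from compound 3 to compound 4 (0.42 log units; beyond the scatter) when it replaces 4-(trifluoromethyl)phenyl, but a 1.6-fold higher number from compound 2 to compound 4 (0.19 log units; within the scatter) when it replaces 4-chlorophenyl. Among these three benzyl arms on the shared core, only the trifluoromethyl one stands apart. With the 3,5-dimethoxybenzyl group held, chloro in place of fluoro on an aromatic carbon gives a 2.0-fold higher number from compound 1 to compound 4 (0.31 log units; beyond the scatter) as a modest step of its own. On these data alone, whether an amine or a carboxylic acid on the benzyl ring would hold this level remains open. Nothing measured here gives a reason for any of these steps.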